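The source may hold more compounds than are shown below. What is called first, only, known or untested is meant among the compounds shown, and "the series" means these compounds.

Compound 1 `CN(O)/C=C\C(=O)c1ccc2ccccc2c1`, 1800 nM; compound 2 `CN(O)/C=C\C(=O)c1ccc([N+](=O)[O-])cc1`, 1500 nM; compound 3 `O=C(/C=C\N(O)Cc1ccccc1)c1ccc([N+](=O)[O-])cc1`, 2500 nM.

In an assay on RBL-1 cells for inhibition of Polyunsaturated fatty acid 5-lipoxygenase (Rattus norvegicus) (on this read-out lower numbers stand for stronger inhibition and higher numbers for weaker inhibition), compound 3 shows the highest of the three numbers, yet its gaps to compound 1 and to compound 2 both lie within the scatter, so no order among them can be claimed. Among the compounds with values here, the only single-site step among the measured compounds, a 1.7-fold higher number from compound 2 to compound 3 (0.22 log units; within the scatter), concerned the carbon bound to the amine nitrogen and stayed within the scatter. Compound 4 `CC(=O)ON(/C=C\C(=O)c1ccc([N+](=O)[O-])cc1)Cc1ccccc1` differs from compound 3 by acetyl in place of hydrogen on an oxygen. Within the data shown here, no measured step touches that oxygen, so the expectation rests on the structural change alone. The step is expected to be a 2.4-fold higher number from compound 3 to compound 4 (0.38 log units; beyond the scatter), toward a higher number. Compound 4 is estimated at 6000 nM, ranging from 2000 nM to 20000 nM.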

Compound 4, half-maximal inhibitory concentration: > 25000 nM
Compound 4 ended at the assay's limit; the forecaster's own chance of this, stated with the estimate: 15%; middle value at least 4.1-fold (0.61 log units) from the limit.
By their numbers in this assay, from the lowest: compounds 2, 1 and 3 (each within the scatter of the next). At a limit, above all of these: compound 4.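

In this assay, within the data shown here, the oxygen on the amine nitrogen is the first place in these compounds where a single change goes beyond the scatter: hydroxy to acetoxy gives an at least 10-fold higher number from compound 3 to compound 4 (1.00 log units; beyond the scatter). Among these compounds, the one earlier step, a 1.7-fold higher number from compound 2 to compound 3 (0.22 log units; within the scatter), stayed within the scatter. Compound 4 stands at a limit of the assay: the limit of > 25000 nM in this assay, at which 1 of the 4 values shown sits.

As far as these compounds go, what a methyl or a benzoyl on this oxygen would give stays open, so it cannot be told whether this step is specific to acetyl. Also open, from the compounds shown here alone, is whether acetoxy would act alike on compound 1.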